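The compounds below may be only part of what the source reports. "The series", "measured", "known", "first", "only" and "open" are said of these compounds alone.

Measured compounds:
compound 1 `O=C(Nc1ncc(Cc2ccc(Br)cc2)s1)c1ccc2ccccc2c1`: > 50000 nM
compound 2 `O=C(Nc1ncc(C(Oc2ccc3cc(Br)ccc3c2)c2ccc(Cl)cc2)s1)C1CCCO1`: "not toxic" (no number reported)

In an ADME assay on HepG2 2.2.15 cells (Homo sapiens) for cytotoxicity (on this read-out higher numbers stand for lower toxicity in this test and lower numbers for higher toxicity in this test), compound 1 reaches only the upper edge of what the test can see, so its result > 50000 nM is a limit rather than a number. Compound 2, which shares the aminothiazole core but carries a different amide and a larger ether side, is reported only as "not toxic" (no number reported) in this assay, without a figure. So compound 2 stands with compound 1 among the compounds of this set that show no measurable toxicity, consistent with the limit of > 50000 nM in this assay, at which 1 of the 2 values shown sits.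

Compound 3 `CCc1ccc(S(=O)(=O)Nc2ncc(C(Oc3ccc4cc(Br)ccc4c3)c3ccc(Cl)cc3)s2)cc1` differs from compound 2 by one exchange on the same nitrogen: (4-ethylphenyl)sulfonyl in place of (oxolan-2-yl)carbonyl on a nitrogen on an aromatic ring. Among the compounds with values here, no measured pair in this set shows how such a change moves the result in this assay. Given that both measured compounds sit at or beyond the edge of detection, no step beyond the usual scatter is expected in either direction. Compound 3 is therefore expected to give about 50000 nM in this assay, with a plausible range from 20000 nM to 100000 nM, and most likely to be reported again only as a limit.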

Compound 3, half-maximal cytotoxic concentration: > 50000 nM
Compound 3: a limit, no number; the forecaster's own chance of this, stated with the estimate: 70%; the middle value lies on the limit itself.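

In this assay compound 3 gives > 50000 nM, which is a limit and not a number. Compound 2 is reported without any figure, and no step can be read between compound 2 and compound 3. The compounds shown leave open at what concentration, if any, each of them would harm these cells.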